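Chloro to amino on the core of compound 2

This account rests on a few compounds, and the source may have more. Where it says the series, first, only, none or still open, it means among the compounds named here.

Measured so far:
compound 1, `ClCc1ccc(Cn2cnc3c(Cl)ncnc32)cc1`, 640 nM
compound 2, `ClCc1cccc(Cn2cnc3c(Cl)nc(Cl)nc32)c1`, 5880 nM
compound 3, `ClCc1ccccc1Cn1cnc2nc(Cl)nc(Cl)c21`, 34700 nM

In a functional assay on CAKI-1 cells (Homo sapiens) for cytotoxicity, read by sulforhodamine B assay, with a stated time of 48 h (a higher number here means a weaker inhibitor of growth, a lower number a stronger inhibitor of growth), compound 2 gives 5880 nM, the second highest of the three numbers. Compound 3 gives 34700 nM, a higher number than compound 2, and compound 1 gives 640 nM, a lower number than compound 2; both gaps to compound 2 lie beyond the scatter. None of the three pairs differs in one place only, so no single structural change among them is sized.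

The next compound, compound 4, `Nc1nc(Cl)c2ncn(Cc3cccc(CCl)c3)c2n1`, differs from compound 2 in one place: amino in place of chloro on an aromatic carbon. Within the data shown here, no measured pair carries this change, so there is no step to lean on.

With that in mind, the step of a 1.2-fold lower number from compound 2 to compound 4 (0.07 log units; within the scatter) is expected to stay within the scatter, with no clear direction. Compound 4 is therefore estimated at 5000 nM, in a range from 1500 nM to 20000 nM.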

Compound 4, concentration for total growth inhibition: 1510 nM
Beside the measured number, compound 4's estimate is 3.3-fold (0.52 log units) above it; low and high end bracket the measured number.
By their numbers in this assay, from the lowest: compound 1; then compound 4; then compound 2; then compound 3.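

In this assay, the series now has its first sized single-place change, on an aromatic carbon between two ring nitrogen atoms: amino in place of chloro gives a 3.9-fold lower number from compound 2 to compound 4 (0.59 log units; beyond the scatter), a modest step beyond the scatter. Chloro at this place is therefore not required for growth inhibition in these cells, and the swap to amino, which adds a hydrogen-bond donor and acceptor, goes with a lower number rather than a loss. No measured evidence explains the direction or size of this step.

This reading rests on a single pair, with the meta chloro group and the rest of compound 2 unchanged. Going by these compounds, whether the gain is specific to amino remains open: methylamino, dimethylamino, hydroxyl or methoxy at this place would test it, as would hydrogen in place of the chloro.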